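Shifting a Methyl Group in an Antiproliferative Series

The source may hold more compounds than are shown below. What is called first, only, known or untested is meant among the compounds shown, and "the series" means these compounds.

Compound 1 `Cc1ccccc1NNC(=O)c1cccc(NS(=O)(=O)c2cnc(O)nc2O)c1` is the only one of the three measured compounds to return a number: in a functional assay on A549 cells (Homo sapiens) for antiproliferative activity, read by MTT assay, with a stated time of 24 h (on this read-out higher numbers stand for weaker inhibition and lower numbers for stronger inhibition), compound 1 gives 14200 nM. Compound 2 `Cc1cccc(NNC(=O)c2cccc(NS(=O)(=O)c3cnc(O)nc3O)c2)c1` differs from it in one place, (3-methylphenyl in place of 2-methylphenyl on an amine nitrogen). For compound 2 this assay reports only a limit, > 20000 nM. The change gave an at least 1.4-fold higher number from compound 1 to compound 2 (0.14 log units; that floor lies within the scatter). Compound 3 `Cc1ccccc1NNC(=O)c1ccccc1NS(=O)(=O)c1cnc(O)nc1O` has the same atoms as compound 1 joined differently, and the difference between the two cores is not broken down here. For compound 3 this assay likewise reports only a limit, > 20000 nM. Compound 4 `Cc1cccc(NNC(=O)c2ccccc2NS(=O)(=O)c2cnc(O)nc2O)c1` has not been measured; it stands to compound 3 as compound 2 stands to compound 1, with the same change, (3-methylphenyl in place of 2-methylphenyl on an amine nitrogen). Since compound 3 already sits at the limit of > 20000 nM in this assay, at which 2 of the 3 values shown sit, compound 4 is expected to remain there as well, with no number in this assay. The step from compound 3 to compound 4 is estimated at a step that the limit leaves unreadable from compound 3 to compound 4. For compound 4 the expected value in this assay is 30000 nM, between 15000 nM and 60000 nM.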

Compound 4, half-maximal inhibitory concentration: > 20000 nM
Compound 4: a limit, no number; the forecaster's own chance of this, stated with the estimate: 80%; the middle value is on the limit's open side.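

In this assay, among the compounds shown here, compound 4, like compound 3, returns only a limit, so no step between compound 3 and compound 4 can be read: the limit of > 20000 nM in this assay, at which 3 of the 4 values shown sit. The compounds shown leave open whether 3-methylphenyl in place of 2-methylphenyl on an amine nitrogen changes the read-out at all, and how far beyond their limits compound 2, compound 3 and compound 4 lie.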